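The source may report more compounds than this note shows. Statements on the series, on what has been measured and on what is new or still open speak of the compounds shown alone.

Values in a functional assay on MDA-MB-231 cells (Homo sapiens) for antiproliferative activity, read by MTT assay; on this read-out lower numbers stand for stronger inhibition and higher numbers for weaker inhibition:
compound 1 `CC/C=C\C/C=C\C/C=C\CCCCCCCc1cc(=O)c2c(O)c(C)c(O)c(C)c2o1`: 6790 nM
compound 2 `CC/C=C\C/C=C\C/C=C\CCCCCCCc1cc(=O)c2c(O)c(C)c(O)cc2o1`: 6790 nM
compound 3 `CCCC/C=C\CCCCCCCCCc1cc(=O)c2c(O)c(C)c(OCOC)c(C)c2o1`: > 87000 nM, a limit of this assay and not a number

Among the measured compounds shown here, the one measured step is no change at the digits printed from compound 1 to compound 2 (within the scatter), the change being (hydrogen in place of methyl on an aromatic carbon). Compound 3 sits at the limit of > 87000 nM in this assay, at which 1 of the 3 values shown sits, a limit only. The difference between the core of compound 1 and the core of compound 3 is not broken down here.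

Compound 4 `CCCC/C=C\CCCCCCCCCc1cc(=O)c2c(O)cc(OCOC)c(C)c2o1` is not yet measured. Its change from compound 3, (hydrogen in place of methyl on an aromatic carbon), is the same kind of change as that from compound 1 to compound 2, not the same: in compound 4 the place is ortho to a methoxymethoxy group and para to a fused ring, whereas in compound 2 it is ortho to a fused ring and para to a hydroxy group. Given that compound 3 gives only the limit > 87000 nM, and that the earlier step of this kind was no change at the digits printed from compound 1 to compound 2 (within the scatter), the expected step is a step that the limit leaves unreadable from compound 3 to compound 4. Compound 4 is estimated at 120000 nM in this assay, between 40000 nM and 400000 nM, most likely again a limit.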

Compound 4, half-maximal inhibitory concentration: > 87000 nM
Compound 4 was reported as a limit (the forecaster's own chance of this, stated with the estimate: 70%); the middle value is on the limit's open side.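

Compound 3 and compound 4 both sit at a limit and not at a number, so no step between them can be read: the limit of > 87000 nM in this assay, at which 2 of the 4 values shown sit.

The compounds shown leave open what hydrogen in place of methyl on an aromatic carbon does on the core of compound 3.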